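One more acetoxy on compound 2

A few compounds are considered here, and "the series" means these few. Any claim that something is new, unique, unknown or untested is made for them only; others in the source may bear on it.

In a functional assay on KB cells (Homo sapiens) for cytotoxicity, read by sulforhodamine B assay, with a stated time of 72 h (on this read-out lower numbers stand for an effect already at smaller amounts and higher numbers for an effect only at larger amounts of compound), two compounds have been read so far. Compound 1 `CCCC[C@@H](/C=C\[C@@H]1OC(=O)C[C@@H](OC)[C@@H]1O)OC(C)=O` is reported as > 20 ug/mL and this is a limit of the assay, not a number. Among the measured compounds shown here, compound 2 `CCCC[C@H](OC(C)=O)[C@@H](OC(C)=O)[C@H](OC(C)=O)[C@H]1CC=CC(=O)O1` gives 4 ug/mL as the only true number available, so it has a measured position.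

Compound 3 `CCCC[C@H](OC(C)=O)[C@@H](OC(C)=O)[C@H](OC(C)=O)[C@@H]1OC(=O)C=C[C@@H]1OC(C)=O` is compound 2 with one structural change. That change is acetoxy in place of hydrogen on a saturated ring carbon and in words it is acetoxy in place of hydrogen on a saturated ring carbon, next to the ring atom that bears a large group and two ring bonds from the ring oxygen.

For the measured compounds named here, no measured pair isolates this change. The expectation therefore rests on compound 2 at 4 ug/mL alone, and no shift beyond the usual scatter is expected in this assay in either direction. The expected move is a 1.3-fold lower number from compound 2 to compound 3 (0.12 log units; within the scatter) and it remains only an estimate. For compound 3 the expected value is 3 ug/mL with an estimated range from 1 ug/mL to 12 ug/mL as the span of the estimate.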

Compound 3, concentration for half-maximal effect: 4.4 ug/mL
Beside the measured number, compound 3's estimate is 1.5-fold (0.17 log units) below it; measured number inside the range.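

In this assay, acetoxy in place of hydrogen on a saturated ring carbon gives a 1.1-fold higher number from compound 2 to compound 3 (0.04 log units; within the scatter), so at this place, next to the ring atom that bears a large group and two ring bonds from the ring oxygen, the added group leaves the two compounds reading alike. The compounds shown earlier offered no pair differing in one place, and this step is the only direct reading on this position and this change. Nothing shown offers a measured property that would account for this outcome.

Among the compounds shown, acetoxy is the only group other than hydrogen at this ring carbon, so the step says nothing about how a free hydroxyl, a methoxy or a longer ester such as butyryloxy would read there. Going by these compounds, it also remains open whether the same tolerance would hold for an amine at this place, or whether acetoxy would read the same way at any other ring carbon of the shared core.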